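A few compounds are considered here, and "the series" means these few. Any claim that something is new, unique, unknown or untested is made for them only; others in the source may bear on it.

In an assay on CHO-TREX cells for antagonist activity at transient receptor potential cation channel subfamily A member 1 (Homo sapiens), read by FLIPR and calcium flux, with a stated time of 10 min (on this read-out higher numbers stand for weaker inhibition and lower numbers for stronger inhibition), compound 1 `c1ccc(-c2ccc3[nH]ncc3c2)cc1` is reported only as a limit, > 30000 nM, and not as a number. Going by the values given here, compound 2 `FC(F)(F)c1ccccc1-c1ccc2[nH]ncc2c1` gives 164 nM in this assay, and the change an at least 180-fold lower number from compound 1 to compound 2 (2.26 log units; beyond the scatter) is the one large step among the measured compounds. Compound 3 `Fc1ccc(C(F)(F)F)c(-c2ccc3[nH]ncc3c2)c1` gives 306 nM, and the step of a 1.9-fold higher number from compound 2 to compound 3 (0.27 log units; within the scatter) stays within the scatter of the method. Compound 2 therefore holds the lowest of the two numbers shown, with compound 3 nearest to it and only a limit beyond; within that scatter, no order can be set between compound 2 and compound 3.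

Compound 4 `CNC(=O)c1cc2[nH]ncc2cc1-c1ccccc1C(F)(F)F` differs from compound 2 in one place: methylcarbamoyl in place of hydrogen on an aromatic carbon. Neither measured step introduces such a group. The large step from compound 1 to compound 2 concerns a trifluoromethyl group, which compound 4 keeps, and the step from compound 2 to compound 3 shows that a small added substituent moved the number only within the scatter. Among the compounds with values here, with no closer precedent, the account expects the number for compound 4 to stay near that of compound 2, a step of a 1.0-fold lower number from compound 2 to compound 4 (0.01 log units; within the scatter) that need not exceed the scatter in either direction. The estimate for compound 4 in this assay is 160 nM, with a range from 50 nM to 600 nM.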

Compound 4, half-maximal inhibitory concentration: > 30000 nM
Compound 4: only a limit was reported (the forecaster's own chance of this, stated with the estimate: 5%); at least 180-fold (2.27 log units) between middle value and limit.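

In this assay, methylcarbamoyl in place of hydrogen on an aromatic carbon of the shared core, ortho to a large group, gives an at least 180-fold higher number from compound 2 to compound 4 (2.26 log units; beyond the scatter). This is the first large step among the compounds shown that starts from compound 2, and it shows that keeping the trifluoromethyl group is not enough to hold the number of compound 2 once this substituent enters at this position. Compound 4 is reported only as a limit, so the step gives a minimum size and not a full one: the limit of > 30000 nM in this assay, at which 2 of the 4 values shown sit.

The compounds shown leave open whether the whole methylcarbamoyl group or only a part of it accounts for the step, a question that a primary carboxamide, a methyl, a methoxy or a nitrile on the same aromatic carbon could help to separate. They also leave open whether methylcarbamoyl on another carbon of the core, or an amine or a carboxylic acid at this position, would give a similar result.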